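From Cyano to Trifluoromethoxy in Compound 4

The source may hold more compounds than are shown below. What is called first, only, known or untested is meant among the compounds shown, and "the series" means these compounds.

In a functional assay on MDA-MB-231 cells (Homo sapiens) for antiproliferative activity, read by MTT assay, with a stated time of 48 h (on this read-out lower numbers stand for stronger inhibition and higher numbers for weaker inhibition), compound 1 (`CCCNC(=O)N1CCN(c2ncnc3sc(-c4ccc(N5CCN(C)CC5)cc4)cc23)CC1`) gives 8330 nM and compound 2 (`COc1ccc(NC(=O)N2CCN(c3ncnc4sc(-c5ccc(N6CCN(C)CC6)cc5)cc34)CC2)cc1`) gives 20900 nM while compound 3 (`CN1CCN(c2ccc(-c3cc4c(N5CCN(C(=O)Nc6ccc(C#N)cc6)CC5)ncnc4s3)cc2)CC1`) gives 3930 nM as the lowest of the three numbers. Compound 4 (`CN1CCN(c2ccc(-c3cc4c(N5CCN(C(=O)Nc6ccc(OC(F)(F)F)cc6)CC5)ncnc4s3)cc2)CC1`) has not yet been measured. It differs from compound 3 by having trifluoromethoxy in place of cyano on an aromatic carbon, para to a large group (trifluoromethoxy in place of cyano on an aromatic carbon).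

The closest measured change puts cyano in place of methoxy on that carbon (a 5.3-fold lower number from compound 2 to compound 3 (0.73 log units; beyond the scatter)) and is modest. Swapping propyl for 4-methoxyphenyl (a 2.5-fold higher number from compound 1 to compound 2 (0.40 log units; beyond the scatter)) or 4-cyanophenyl (a 2.1-fold lower number from compound 1 to compound 3 (0.33 log units; beyond the scatter)) was also modest, and the two went in opposite directions. Going by the values given here, no measured compound carries trifluoromethoxy, so the direction is uncertain. Still, trifluoromethoxy shares its oxygen with methoxy, which suggests a move toward compound 2 (20900 nM) rather than away from it. Thus a 1.8-fold higher number from compound 3 to compound 4 (0.25 log units; within the scatter) is expected in this assay as a small step. For compound 4 the estimate is 7000 nM with an expected range from 2500 nM to 20000 nM as its ends.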

Compound 4, half-maximal inhibitory concentration: 4600 nM
The estimate for compound 4 lay 1.5-fold (0.18 log units) above the measured number, and the stated range covers the measured number.
By their numbers in this assay, from the lowest: compounds 3, 4 and 1 (each within the scatter of the next, the first and the last beyond it); then compound 2.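

In this assay, trifluoromethoxy in place of cyano on this aromatic carbon gives a 1.2-fold higher number from compound 3 to compound 4 (0.07 log units; within the scatter), so these two groups cannot be told apart at this position, although trifluoromethoxy is the larger by heavy atoms. Trifluoromethyl in place of methyl on the oxygen gives a 4.5-fold lower number from compound 2 to compound 4 (0.66 log units; beyond the scatter), which shows that an oxygen on this carbon does not by itself go with the high number of compound 2; what sits on that oxygen matters. 4-(Trifluoromethoxy)phenyl in place of propyl gives a 1.8-fold lower number from compound 1 to compound 4 (0.26 log units; within the scatter), so this aryl group and propyl also cannot be told apart here.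

Nothing available explains these results. From the compounds shown here alone, how an amine or a carboxylic acid on this carbon would compare remains open, as does the effect of a longer chain in place of propyl.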